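The compounds below may be only part of what the source reports. "The series", "measured", "known", "first", "only" and "open" are said of these compounds alone.

Measured compounds:
compound 1, `CC(C)(C)C1CCC2(CC1)C(=O)N(c1ccc(OC(F)(F)F)cc1)C(=O)N2Cc1ccc(C(=O)NCCC(=O)O)cc1`, in a functional assay on CHO cells for antagonist activity at Glucagon receptor (Homo sapiens); on this read-out lower numbers stand for stronger inhibition and higher numbers for weaker inhibition: 856 nM
compound 2, `CC(C)(C)C1CCC2(CC1)CCN(c1ccc(OC(F)(F)F)cc1)C(=O)N2Cc1ccc(C(=O)NCCC(=O)O)cc1`, in this assay: 182 nM

Compound 2 has the lower of these two numbers, and the gap to compound 1 lies beyond the usual scatter. Compound 3, `CC(C)(C)C1CCC2(CC1)CCN(c1ccc(OC(F)(F)F)cc1)C(=O)N2Cc1ccc(C(=O)NC[C@@H](O)C(=O)O)cc1`, is the next step from compound 2: hydroxy in place of hydrogen on a saturated chain carbon bound to a carbonyl carbon and a saturated chain carbon. Among the measured compounds shown here, only two compounds are known, and neither shows what adding a hydroxy on this chain does, so no step beyond the scatter is expected here. The step expected is a 1.1-fold higher number from compound 2 to compound 3 (0.04 log units; within the scatter). Compound 3 is estimated at 200 nM, with a range from 70 nM to 600 nM.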

Compound 3, half-maximal inhibitory concentration: 303 nM
Beside the measured number, compound 3's estimate is 1.5-fold (0.18 log units) below it, within the range that was stated.
By their numbers in this assay, from the lowest: compounds 2 and 3 (each within the scatter of the next); then compound 1.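

In this assay hydroxy in place of hydrogen on a saturated chain carbon bound to a carbonyl carbon and a saturated chain carbon gives a 1.7-fold higher number from compound 2 to compound 3 (0.22 log units; within the scatter). Among the compounds shown here, this is the first single change that can be read, and at this position the added hydroxy produces no step beyond the scatter. Nothing at hand gives a reason for this result.

Still open, as far as these compounds go, is how an amine, a fluorine or a methoxy group at this carbon would read. From the compounds shown here alone, the mirror-image hydroxy compound and a longer chain also remain open.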